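The source may report more compounds than this note shows. Statements on the series, on what has been measured and on what is new or still open speak of the compounds shown alone.

Of the compounds shown here, two in this set have been measured. Compound 1 `COc1ccc(OC)c(/C=C/c2nnc(Nc3ccc(Cl)cc3)o2)c1` and compound 2 `COc1ccc(OC)c(/C=C/C(=O)N/N=C/c2ccc(Cl)cc2)c1` share the same dimethoxyphenyl vinyl portion and a chlorinated aromatic ring at the far end, but are linked through different middle parts. In a functional assay on Hs-578T cells (Homo sapiens) for antiproliferative activity, read by sulforhodamine B assay, with a stated time of 48 h (a higher number here means that more compound is tolerated, a lower number that less compound is tolerated), compound 1 gives only a limit of the assay, > 100000 nM, and no number. Compound 2 likewise gives only a limit in this assay, > 100000 nM. Both measured values sit at the same point: the limit of > 100000 nM in this assay, at which 2 of the 2 values shown sit. So compound 2 stands at the top edge of what this assay can report, alongside compound 1, and no step between the two measured compounds has been worked out.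

Compound 3 `COc1ccc(OC)c(/C=C/C(=O)N/N=C/c2ccccc2)c1` is the next compound to be measured. It differs from compound 2 by hydrogen in place of chloro on an aromatic carbon. Since compound 2 reached only a limit in this assay (> 100000 nM), a small structural change of this kind is expected to give no step beyond the usual scatter. Compound 3 is therefore expected to reach about 150000 nM, within a range from 40000 nM to 500000 nM. The expected step, a step that the limit leaves unreadable from compound 2 to compound 3, would stay inside the scatter.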

Compound 3, concentration lethal to 50% of the cells: > 100000 nM
Compound 3: a limit, no number; the forecaster's own chance of this, stated with the estimate: 80%; the middle value is on the limit's open side.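

Compound 2 and compound 3 each give only a limit of the assay and no number in this assay, so no step can be read between them: the limit of > 100000 nM in this assay, at which 3 of the 3 values shown sit.

The compounds shown leave open whether going from 4-chlorophenyl to phenyl changes the effect on these cells at all, and which change to these structures would bring a value inside the range of the assay.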